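Methyl to nitro on a benzyl indole: two placements compared

The source may report more compounds than this note shows. Statements on the series, on what has been measured and on what is new or still open speak of the compounds shown alone.

Compound 1 `Cc1cccc(Cn2cc(CO)c3ccccc32)c1`: 1000 nM
Compound 2 `Cc1ccc(Cn2cc(CO)c3ccccc32)cc1`: 150 nM
Compound 3 `O=[N+]([O-])c1cccc(Cn2cc(CO)c3ccccc32)c1`: 390 nM

In a functional assay on T29Kt1 cells (Homo sapiens) for cytotoxicity, read by sulforhodamine B assay, with a stated time of 3 days (a lower number here means a stronger inhibitor, a higher number a weaker inhibitor), compound 2 gives the lowest of the three numbers; the difference between its core and the core of compound 1 is not broken down here. Compound 1 and compound 3 differ by nitro in place of methyl on an aromatic carbon, and this change gave a 2.6-fold lower number from compound 1 to compound 3 (0.41 log units; beyond the scatter). Compound 4 `O=[N+]([O-])c1ccc(Cn2cc(CO)c3ccccc32)cc1` stands to compound 2 in the same kind of change, (nitro in place of methyl on an aromatic carbon), but the place differs: here the nitro sits para to a large group, whereas in compound 3 it sits meta to a large group. Because the step of a 2.6-fold lower number from compound 1 to compound 3 (0.41 log units; beyond the scatter) went toward lower numbers, a step of similar direction, a 1.9-fold lower number from compound 2 to compound 4 (0.27 log units; within the scatter), is expected for compound 4, though the different place makes its size uncertain. Compound 4 is estimated at 80 nM, between 30 nM and 250 nM.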

Compound 4, half-maximal inhibitory concentration: 150 nM
The estimate for compound 4 lay 1.9-fold (0.27 log units) below the measured number; low and high end bracket the measured number.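

In this assay, nitro in place of methyl gave no change at the digits printed from compound 2 to compound 4 (within the scatter). Set beside the earlier step, this one does not differ from it by more than repeated measurement allows: the same change on two cores in this assay, a 2.6-fold lower number (0.41 log units; beyond the scatter) from compound 1 to compound 3 and no change at the digits printed (within the scatter) from compound 2 to compound 4, 2.6-fold (0.41 log units) apart, within the scatter of two such steps. The change can therefore be said to behave alike on the two cores as far as these values can tell, but two pairs do not establish that its step is the same on both, and they cannot separate the core from the place of the nitro, since both differ.

The compounds shown leave open how other groups on that aromatic carbon would read. An amine, a nitrile or a carboxylic acid in place of the methyl could be set against the nitro on either core.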